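The compounds below may be only part of what the source reports. "The series", "measured", "known", "first", "only" and "open" are said of these compounds alone.

Of the compounds shown here, two sharing one core have been measured so far in a functional assay on CCRF-CEM cells (Homo sapiens), read by MTT assay, with a stated time of 72 h; a higher number here means a weaker inhibitor, a lower number a stronger inhibitor. Compound 1 `CSc1ncnc2c1c(-c1ccoc1)cn2[C@@H]1O[C@H](CO)[C@@H](O)[C@H]1O` gives 14200 nM, and compound 2 `CNc1ncnc2c1c(-c1ccco1)cn2[C@@H]1O[C@H](CO)[C@@H](O)[C@H]1O` gives 180 nM. Compound 2 therefore holds the lower of the two numbers, and its gap to compound 1 lies well beyond the scatter of repeated measurements. For the measured compounds named here, no measured pair differs in one place only, so the data offer no direct guide to a single change.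

Compound 3 `CNc1ncnc2c1c(-c1ccoc1)cn2[C@@H]1O[C@H](CO)[C@@H](O)[C@H]1O` has not yet been measured. It differs from compound 2 in one group, with furan-3-yl in place of furan-2-yl on an aromatic carbon. The two compounds have the same atoms, joined differently. With so small a change, the natural starting point is compound 2 at 180 nM, and a modest move toward a weaker inhibitor in this assay is expected rather than a large jump. The estimated step is a 2.2-fold higher number from compound 2 to compound 3 (0.35 log units; beyond the scatter). For compound 3 the expected value is 400 nM, with an estimated range from 100 nM to 2500 nM.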

Compound 3, half-maximal inhibitory concentration: > 20000 nM
Compound 3: only a limit was reported (the forecaster's own chance of this, stated with the estimate: 3%); middle value at least 50-fold (1.69 log units) from the limit.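

In this assay compound 3 gives only a limit, not a number: the limit of > 20000 nM in this assay, at which 1 of the 3 values shown sits. Replacing furan-2-yl with furan-3-yl keeps the same atoms and changes only how the furan ring is joined to the shared core, yet it gives an at least 110-fold higher number from compound 2 to compound 3 (2.04 log units; beyond the scatter), so with methylamino held constant, this attachment matters greatly at this position on the five-membered aromatic ring. With furan-3-yl held constant, methylamino in place of methylsulfanyl gives an at least 1.4-fold higher number from compound 1 to compound 3 (0.14 log units; that floor lies within the scatter), so this pair shows no gain from methylamino, and the swap does not restore a low number when furan-3-yl is present.

The compounds shown leave open whether this sharp sensitivity belongs to furan rings alone or would also appear with another ring at this place, such as thiophen-2-yl, thiophen-3-yl or a phenyl group. They also leave open how methylsulfanyl behaves alongside furan-2-yl, and whether a plain amino group or a dimethylamino group in place of methylamino would alter the result with either furan.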